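Replacing the nitro group of compound 1 with an amide-bearing side chain

The source may hold more compounds than are shown below. What is called first, only, known or untested is meant among the compounds shown, and "the series" means these compounds.

The account concerns a small set of compounds built on a shared core and tested in an ADME assay on BHK cells (Mesocricetus auratus) for cytotoxicity, read by MTT assay, with a stated time of 96 h; a lower number here means that less compound is tolerated, a higher number that more compound is tolerated. Compound 1, whose structure is `Cn1c(-c2ccc([N+](=O)[O-])cc2)nc2cc(C(F)(F)F)ccc21`, carries a nitro group on its phenyl ring and a methyl on an aromatic nitrogen. In this assay compound 1 gives > 100000 nM, which is a limit of the assay rather than a number (the limit of > 100000 nM in this assay, at which 1 of the 2 values shown sits); compound 1 therefore stands at the least toxic end of what has been measured. Compound 2, with structure `O=[N+]([O-])c1ccc(-c2nc3cc(C(F)(F)F)ccc3[nH]2)cc1`, differs from compound 1 only in having hydrogen in place of methyl on the aromatic nitrogen, and in this assay compound 2 gives 18000 nM. Within the data shown here, the step of an at least 5.5-fold lower number from compound 1 to compound 2 (0.74 log units; beyond the scatter) is the only measured step in the set.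

Compound 3, with structure `CCN(CC)CC(=O)Nc1ccc(-c2nc3cc(C(F)(F)F)ccc3n2C)cc1`, is not yet measured in this assay. It differs from compound 1 as follows: (((diethylamino)methyl)carbonyl)amino in place of nitro on an aromatic carbon. Among the measured compounds shown here, no measured step touches this position, since the one known step concerns the aromatic nitrogen alone, so there is no direct guide to the size or direction of the change in this assay. Compound 3 is therefore expected to stay near compound 1, an estimated step of a number no higher from compound 1 to compound 3 (the limit leaves the size open), with an estimate of 100000 nM, in the range 30000 nM to 300000 nM.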

Compound 3, half-maximal cytotoxic concentration: 16000 nM
Estimate against measurement, compound 3: 6.3-fold (0.80 log units) above, and the stated range ends above it.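

The change from nitro to (((diethylamino)methyl)carbonyl)amino gives an at least 6.2-fold lower number from compound 1 to compound 3 (0.79 log units; beyond the scatter), so in this assay this aromatic carbon, para to a large group, is a second place where a single change moves the number, alongside the aromatic nitrogen. The entering group differs from nitro in several counted ways, with 9 heavy atoms against 3 and 1 hydrogen-bond donor where nitro has none, and this one step cannot show which of these differences matters. The full size of the step stays unknown, as the value for compound 1 is a limit of the assay and not a number: the limit of > 100000 nM in this assay, at which 1 of the 3 values shown sits.

The compounds shown leave open whether the lower number goes with the amide or with the diethylamino end of the side chain, which a side chain ending in a carboxylic acid, or a longer chain carrying the same amine, would help to separate. Also open, as far as these compounds go, is whether hydrogen in place of methyl on the aromatic nitrogen lowers the number in the same way when the (((diethylamino)methyl)carbonyl)amino group is present on the aromatic carbon.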